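Dichlorophenyl in Place of Dimethoxyphenyl on a Saturated Ring Carbon

This account rests on a few compounds, and the source may have more. Where it says the series, first, only, none or still open, it means among the compounds named here.

Compound 2 `COc1ccc(C2OC(c3cc(OC)c(OC)c(OC)c3)=NN2C(C)=O)c(OC)c1` was tested in a functional assay on PC-3 cells (Homo sapiens) for antiproliferative activity, read by MTT assay, tested at 5 uM (a higher number here means a stronger effect of the compound at the concentration tested, a lower number a weaker effect), and gives 92%. Among the three measured compounds this is the second highest number. Its nearest neighbour, compound 1 `COc1cc(C2=NN(C(C)=O)C(c3cc(Cl)cc(Cl)c3)O2)cc(OC)c1OC`, gives 93.9%, a difference within the scatter of repeated measurements. The furthest, compound 3 `COc1cc(C2=NN(C(C)=O)C(c3cc(OC)c(OC)c(OC)c3)O2)cc(OC)c1OC`, gives 0.1%, far beyond the scatter and close to no effect at all.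

Compound 4 `COc1cc(C2=NN(C(C)=O)C(c3ccc(Cl)c(Cl)c3)O2)cc(OC)c1OC` is not yet measured. It differs from compound 2 in one place: 3,4-dichlorophenyl in place of 2,4-dimethoxyphenyl on a saturated ring carbon. Going by the values given here, the one measured step that bears on this change is a number 1.9 percentage points lower from compound 1 to compound 2 (within the scatter), where a dichlorophenyl group on the same saturated ring carbon gave much the same result as the dimethoxyphenyl group. Compound 3 shows that a trimethoxyphenyl group there goes with almost no inhibition, but that is a different replacement. A step of about zero, none beyond the scatter, is therefore expected for compound 4, whose estimated value is 90% with a range from 70% to 97%. For compound 4 the expected step is a number 2 percentage points lower from compound 2 to compound 4 (within the scatter).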

Compound 4, a percentage reported as inhibition, at one concentration (the size of the read-out at that concentration, not a potency): 26.1%
Estimate against measurement, compound 4: 63.9 percentage points above; the whole stated range lies above it.
By their numbers in this assay, from the lowest: compound 3; then compound 4; then compounds 2 and 1 (each within the scatter of the next).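

In this assay, the 3,4-dichlorophenyl group on the saturated ring carbon gives a number 65.9 percentage points lower from compound 2 to compound 4 (beyond the scatter), so this position does not accept every replacement for 2,4-dimethoxyphenyl. The change of 3,4-dichlorophenyl in place of 3,5-dichlorophenyl gives a number 67.8 percentage points lower from compound 1 to compound 4 (beyond the scatter), which shows that two chlorine atoms on this phenyl ring do not by themselves secure a high read-out: their placement on the ring goes with a large difference. No measurement at hand offers an explanation for either drop.

Still open, from the compounds shown here alone, is how a phenyl ring with a single chlorine, or a pyridine ring, would read at this carbon. All these numbers also come from a single concentration, so they leave open whether the gaps between these compounds would persist at other concentrations.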